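The compounds below may be only part of what the source reports. "The series", "measured", "known", "first", "only" and "open" are said of these compounds alone.

Working notes on the series. Among the compounds with values here, compound 1 `CNC(=O)CCCCCCCn1nc(-c2ccc3oc(N)nc3c2)c2c(N)ncnc21` is the only member with a number: in a functional assay on HeLa cells (Homo sapiens) for inhibition, read by MTT assay, with a stated time of 72 h (on this read-out lower numbers stand for stronger inhibition and higher numbers for weaker inhibition), compound 1 gives 12900 nM, so it stands alone and there is no ranking to speak of. Compound 2 `Nc1ncnc2c1c(-c1cnc3[nH]ccc3c1)nn2CCCC(=O)NO` belongs to the same set, but in this assay compound 2 gives "not determined" (no result reported), so no result was reported for it. Compound 3 `Nc1nc2cc(-c3nn(CCCCCC(=O)NO)c4ncnc(N)c34)ccc2o1` differs from compound 1 in one place: hydroxycarbamoyl in place of 2-(methylcarbamoyl)ethyl on a saturated chain carbon, five bonds along the chain from an aromatic nitrogen. Within the data shown here, no measured pair shows this change, so its effect is unknown here. The expectation is nonetheless a step beyond the scatter toward stronger inhibition, a 5.2-fold lower number from compound 1 to compound 3 (0.71 log units; beyond the scatter). Compound 3 is therefore estimated at 2500 nM in this assay, within 500 nM to 12000 nM.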

Compound 3, half-maximal inhibitory concentration: 15400 nM
Compound 3: the middle estimate sits 6.2-fold (0.79 log units) below what was measured; the measured number lies above the stated range.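

Within the data shown here, the first measured pair at this position gives, in this assay, a 1.2-fold higher number from compound 1 to compound 3 (0.08 log units; within the scatter) for hydroxycarbamoyl in place of 2-(methylcarbamoyl)ethyl on a saturated chain carbon, so this change does not separate the two compounds on this read-out. Nothing available bears on why this is so. As far as these compounds go, whether a carboxylic acid or a primary amine in place of hydroxycarbamoyl would separate from compound 1 remains open. So does the outcome of a longer chain carrying hydroxycarbamoyl.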